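The source may hold more compounds than are shown below. What is called first, only, known or untested is meant among the compounds shown, and "the series" means these compounds.

Working notes on the series

The shared core is carried by compound 1 `Nc1cc(N)c2nc(-c3ccccc3)c(NCc3ccc(Cl)c(Cl)c3)nc2c1`, compound 2 `CCOC(=O)[C@H](CCC(=O)O)NC(=O)c1ccc(Sc2nc3cc(N)cc(N)c3nc2-c2ccccc2)cc1` and compound 3 `CCOC(=O)[C@H](CCC(=O)O)NC(=O)c1ccc(Oc2nc3cc(N)cc(N)c3nc2-c2ccccc2)cc1`, and all three have been run in a functional assay on NCI-H23 cells (Homo sapiens) for inhibition, read by sulforhodamine B assay, with a stated time of 48 h; on this read-out higher numbers stand for weaker inhibition of growth and lower numbers for stronger inhibition of growth. In this assay compound 1 gives 27500 nM. Compound 2 gives 33900 nM and compound 3 gives 30200 nM. Going by the values given here, the three numbers sit within the usual scatter of one another, so compound 1 cannot be set apart from compound 2 or compound 3 on these data: the set reads as a single level of growth inhibition, and no step between any two of these measured compounds is established.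

Compound 4 `COc1ccc(CNc2nc3cc(N)cc(N)c3nc2-c2ccccc2)cc1` has not yet been measured in this assay. It differs from compound 1 in one place: 4-methoxyphenyl in place of 3,4-dichlorophenyl on a saturated chain carbon bound to a nitrogen on an aromatic ring. Among the compounds with values here, nothing among the measured compounds speaks to this exchange, since compound 2 and compound 3 change a different part of the core. Within the data shown here, with no step of this kind to lean on, the expectation for compound 4 is a step from compound 1 of a 1.1-fold higher number from compound 1 to compound 4 (0.04 log units; within the scatter), that is, none beyond the scatter. The estimate for compound 4 in this assay is therefore 30000 nM, with a range from 10000 nM to 90000 nM that leaves room for a moderate move in either direction.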

Compound 4, concentration for total growth inhibition: 34700 nM
The estimate for compound 4 lay 1.2-fold (0.06 log units) below the measured number; the range from low to high includes it.
By their numbers in this assay, from the lowest: compounds 1, 3, 2 and 4 (each within the scatter of the next).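

Going by these compounds alone, the exchange of 3,4-dichlorophenyl for 4-methoxyphenyl on a saturated chain carbon bound to a nitrogen on an aromatic ring gives, in this assay, a 1.3-fold higher number from compound 1 to compound 4 (0.10 log units; within the scatter), the first direct reading at this position. The two groups cannot be told apart on this read-out, even though chlorine gives way to oxygen and the entering group carries a hydrogen-bond acceptor that the leaving group lacks. This one exchange therefore leaves growth inhibition at the level already seen, a finding that holds for 3,4-dichlorobenzyl and 4-methoxybenzyl only, and no information from outside this read-out is available to interpret it.

Open, as far as these compounds go, is whether a group of another kind at this position, such as a carboxylic acid or an amine on the aromatic ring, or a morpholine in place of that ring, would produce a step beyond the scatter. Equally open, from the compounds shown here alone, is whether a longer chain in place of the saturated chain carbon would leave the number at this same level.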